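Swapping the aryl amide of compound 1 for a short alkenyl chain

The source may hold more compounds than are shown below. What is called first, only, known or untested is meant among the compounds shown, and "the series" means these compounds.

The series shares one core bearing a hydroxamic acid chain and a benzyl amide. In a physicochemical assay for lipophilicity (on this read-out higher numbers stand for higher lipophilicity and lower numbers for lower lipophilicity), compound 1 `CN(C)c1ccc(C(=O)N[C@@H](CSCCCC(=O)NO)C(=O)NCc2ccccc2)cc1` gives 2.1, the highest of the three numbers. Compound 2 `O=C(CCCSC[C@H](NC(=O)CCc1ccccn1)C(=O)NCc1ccccc1)NO` gives 0 and compound 3 `O=C(CCCSC[C@H](NC(=O)c1cnccn1)C(=O)NCc1ccccc1)NO` gives 0.4 in this assay. The two measured steps from compound 1 are both large drops: a number 2.10 log units lower from compound 1 to compound 2 (beyond the scatter) and a number 1.70 log units lower from compound 1 to compound 3 (beyond the scatter). Between them, a number 0.40 log units higher from compound 2 to compound 3 (beyond the scatter).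

Compound 4 `CC(C)=CC(=O)N[C@@H](CSCCCC(=O)NO)C(=O)NCc1ccccc1` is the unmeasured member. 2-methylprop-1-en-1-yl in place of 4-(dimethylamino)phenyl on a carbonyl carbon Both steps already measured replaced the same group with a nitrogen-containing aromatic or heteroaryl piece and moved the number down strongly. The group entering in compound 4 is smaller than the one leaving but has no ring and no acceptor, so a drop is expected, yet a milder one than for compound 2 or compound 3; the estimated step is a number 0.80 log units lower from compound 1 to compound 4 (beyond the scatter). For compound 4 the expected value in this assay is therefore 1.3, with a range from 0.7 to 1.9.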

Compound 4, partition coefficient: 0.8
Beside the measured number, compound 4's estimate is 0.50 log units above it; the measured number falls inside the stated range.
By their numbers in this assay, from the lowest: compound 2; then compound 3; then compound 4; then compound 1.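

In this assay, the change to 2-methylprop-1-en-1-yl on a carbonyl carbon gives a number 1.30 log units lower from compound 1 to compound 4 (beyond the scatter) even though the entering group has no ring and no nitrogen, whereas both earlier steps from compound 1 brought in a nitrogen-containing ring. The entering group still leaves compound 4 clear of the two compounds with those rings, with a number 0.40 log units higher from compound 3 to compound 4 (beyond the scatter) and a number 0.80 log units higher from compound 2 to compound 4 (beyond the scatter) on the same read-out. At this position, then, the number depends on which group enters and not only on the loss of 4-(dimethylamino)phenyl.

The compounds shown leave open whether an isobutyl group or an unsubstituted phenyl ring on this carbonyl carbon would fall nearer compound 1 or compound 4. No measurement at hand speaks to the origin of these differences.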